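Enantiomer of the arachidonate dioxolane ester in a lipase screen

The source may hold more compounds than are shown below. What is called first, only, known or untested is meant among the compounds shown, and "the series" means these compounds.

Three esters have been run in an assay on membranes from cerebellum for inhibition of Monoglyceride lipase (Rattus norvegicus), tested at 100 uM; a higher number here means more inhibition at the concentration tested (going by the name of the read-out), a lower number less inhibition. Compound 1 `CCCCC/C=C\C/C=C\C/C=C\C/C=C\CCCC(=O)OC[C@@H]1COC(C)(C)O1` gives 38% and stands second highest of the three; compound 2 `O=C(OCC1CCCCO1)c1cccc(-c2ccccc2)c1` gives 49%, a value beyond the scatter above it, while compound 3 `O=C(OCC1CO1)c1ccccc1` gives 0.2%, far below. Compound 4 `CCCCC/C=C\C/C=C\C/C=C\C/C=C\CCCC(=O)OC[C@H]1COC(C)(C)O1` is the unmeasured mirror-image partner of compound 1 at the ring: the two compounds have the same atoms and bonds and differ only in configuration as drawn: 1 of 5 stereo elements differ; a stereocentre at a saturated ring carbon is drawn S in compound 1 and R in compound 4. For the measured compounds named here, no pair of measured compounds differing only in configuration exists here, so no size for such a step can be read from the set. The expectation is a step no larger than the scatter in this assay, no change at the digits printed from compound 1 to compound 4 (within the scatter), in no settled direction. Compound 4 is therefore estimated at 38%, within 20% to 56%.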

Compound 4, a percentage reported as inhibition, at one concentration (the size of the read-out at that concentration, not a potency): 34%
Estimate against measurement, compound 4: 4 percentage points above; the measured number falls inside the stated range.
By their numbers in this assay, from the lowest: compound 3; then compounds 4 and 1 (each within the scatter of the next); then compound 2.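

In this assay, for the compounds shown here, the first matched pair of the series gives a number 4 percentage points lower from compound 1 to compound 4 (within the scatter). At the tested concentration, this read-out does not separate the S and R forms at the saturated ring carbon, so the drawn configuration there gives no measurable handle in this series. This pair isolates that single stereocentre: the fact that compounds 1 and 4 differ only in the configuration as drawn

A read-out at one concentration leaves open whether the two forms also match in potency. Also open, from the compounds shown here alone, is whether an amide in place of the ester would show the same lack of separation between the two configurations.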